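This account rests on a few compounds, and the source may have more. Where it says the series, first, only, none or still open, it means among the compounds named here.

Measured so far:
compound 1 `CCCNC(=O)/N=C(\N)Nc1cccc(-c2csc(N)n2)c1` — 5250 nM
compound 2 `Cc1nc(N)sc1CCCN/C(N)=N/C(=O)NC(C)c1ccc(Br)cc1` — 30.2 nM
compound 3 `CCCCCCNC(=O)/N=C(\N)NCCCc1sc(N)nc1C` — 28.8 nM

In an assay on membranes from Sf9 cells for displacement of a labelled ligand from histamine H2 receptor (Homo sapiens), read by scintillation counting, with a stated time of 60 min (on this read-out lower numbers stand for stronger inhibition and higher numbers for weaker inhibition), compound 2 gives 30.2 nM, the second highest of the three numbers. Compound 3 gives 28.8 nM, which lies within the scatter of the number for compound 2, so no order can be read between the two. Compound 1 gives 5250 nM, far beyond the scatter above compound 2. Compound 4 `COc1ccc(C(C)NC(=O)/N=C(\N)NCCCc2sc(N)nc2C)cc1` has not yet been measured in this assay. It differs from compound 2 in a single place: methoxy in place of bromo on an aromatic carbon. Among the compounds with values here, no measured pair shows this exchange, so only a small step is expected, most likely none beyond the scatter, if anything toward a slightly higher number. The expected step is a 1.3-fold higher number from compound 2 to compound 4 (0.12 log units; within the scatter). Compound 4 is estimated at 40 nM, with a range from 15 nM to 120 nM.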

Compound 4, inhibition constant: 37.2 nM
Compound 4: middle estimate off by 1.1-fold (0.03 log units), on the high side; measured number inside the range.
By their numbers in this assay, from the lowest: compounds 3, 2 and 4 (each within the scatter of the next); then compound 1.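

Going from 4-bromophenyl to 4-methoxyphenyl gives (a 1.2-fold higher number from compound 2 to compound 4 (0.09 log units; within the scatter)) in this assay. Within the data shown here, this position therefore accepts methoxy, with its hydrogen-bond acceptor, in place of bromo without a change that can be told from the scatter, which the earlier compounds, with no such pair, could not show. Nothing at hand bears on the reason for this result.

As far as these compounds go, whether an amine or a carboxylic acid at this place would leave the number as close remains open. So does the outcome with a longer chain such as butoxy.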